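Triazole substituent stripped to hydrogen in an antiproliferative series

A few compounds are considered here, and "the series" means these few. Any claim that something is new, unique, unknown or untested is made for them only; others in the source may bear on it.

Measured so far:
Compound 1, `O=C1O[C@H]([C@@H](O)Cn2cc(CNS(=O)(=O)c3ccc(F)cc3)nn2)C(OCc2ccccc2)=C1OCc1ccccc1` — 18300 nM
Compound 2, `CCCCCCCCCCc1cn(C[C@H](O)[C@H]2OC(=O)C(OCc3ccccc3)=C2OCc2ccccc2)nn1` — 12200 nM
Compound 3, `O=C1O[C@H]([C@@H](O)Cn2cc(-c3cc(F)cc(F)c3)nn2)C(OCc2ccccc2)=C1OCc1ccccc1` — 11600 nM

In a functional assay on HepG2 cells (Homo sapiens) for antiproliferative activity, read by MTT assay, with a stated time of 72 h (on this read-out lower numbers stand for stronger inhibition and higher numbers for weaker inhibition), compound 3 gives 11600 nM, the lowest of the three numbers; its nearest neighbour is compound 2, whose 12200 nM is separated from it by a 1.1-fold lower number from compound 2 to compound 3 (0.02 log units; within the scatter), and the furthest is compound 1, separated by a 1.6-fold lower number from compound 1 to compound 3 (0.20 log units; within the scatter). Neither gap exceeds the scatter, so no order among the three can be claimed.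

Compound 4, `O=C1O[C@H]([C@@H](O)Cn2ccnn2)C(OCc2ccccc2)=C1OCc1ccccc1`, differs from compound 3 in one place: hydrogen in place of 3,5-difluorophenyl on an aromatic carbon.

For the measured compounds named here, the steps that bear on this change are those at the same aromatic carbon. From compound 2 to compound 3, a 1.1-fold lower number from compound 2 to compound 3 (0.02 log units; within the scatter), a decyl chain and a 3,5-difluorophenyl gave indistinguishable numbers; from compound 1 to compound 3, a 1.6-fold lower number from compound 1 to compound 3 (0.20 log units; within the scatter), a (((4-fluorophenyl)sulfonyl)amino)methyl group did likewise. Every group tried at this position has left the read-out where it was. Removing the group altogether, leaving a hydrogen, is not covered by any measured step, so a modest weakening cannot be excluded, but no step beyond the scatter is expected: a 1.7-fold higher number from compound 3 to compound 4 (0.24 log units; within the scatter). The estimate for compound 4 is therefore 20000 nM, with a range from 8000 nM to 50000 nM.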

Compound 4, half-maximal inhibitory concentration: > 100000 nM
Compound 4: a limit, no number (the forecaster's own chance of this, stated with the estimate: 15%); at least 5.0-fold (0.69 log units) between middle value and limit.
By their numbers in this assay, from the lowest: compounds 3, 2 and 1 (each within the scatter of the next). At a limit, above all of these: compound 4.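

In this assay, the reading for compound 4 is a limit and not a number: the limit of > 100000 nM in this assay, at which 1 of the 4 values shown sits. The groups at this aromatic carbon had given numbers within the scatter of one another, but replacing them with hydrogen moves the read-out beyond the scatter, with an at least 8.6-fold higher number from compound 3 to compound 4 (0.93 log units; beyond the scatter) for the loss of 3,5-difluorophenyl, an at least 8.1-fold higher number from compound 2 to compound 4 (0.91 log units; beyond the scatter) for the loss of decyl, and an at least 5.4-fold higher number from compound 1 to compound 4 (0.73 log units; beyond the scatter) for the loss of (((4-fluorophenyl)sulfonyl)amino)methyl. For the compounds shown here, the position is therefore not indifferent to change: among the four compounds, the three that carry a group here, however different those groups are, stay clear of the limit, and only the one with hydrogen reaches it.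

The compounds shown do not tell how little is enough at this carbon, as none carries a group between hydrogen and these three in size; a methyl, a hydroxymethyl or an amine here would begin to settle that. They also leave open why hydrogen differs from the three groups, and whether a charged group such as a carboxylic acid would keep the read-out with compounds 1, 2 and 3.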